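Replacing an Amino Group on the Pyridine-Bearing Core

The source may hold more compounds than are shown below. What is called first, only, known or untested is meant among the compounds shown, and "the series" means these compounds.

Measured compounds:
compound 1 `CCCN(CCC)c1cc(C)nc2c(-c3ncc(C(F)(F)F)cc3Cl)c(C)nn12`: 1.2 nM
compound 2 `CCCN(CC1CC1)c1cc(C)nc2c(-c3ncc(Cl)cc3Cl)c(C)nn12`: 3.9 nM
compound 3 `CCCN(CCC)c1cc(C)nc2c(-c3ncc(N)cc3C)c(C)nn12`: 85 nM

In an assay on isolated protein for binding affinity to corticotropin-releasing factor receptor 1 (Homo sapiens) (on this read-out higher numbers stand for weaker inhibition and lower numbers for stronger inhibition), compound 3 stands at the highest of the three numbers. Its nearest neighbour is compound 2, whose value is lower by a margin well beyond the scatter, and compound 1 lies further still below it. Among the measured compounds shown here, compound 3 differs from both in more than one place, so no single step between them can be drawn; the values show only that the two compounds carrying halogen or trifluoromethyl substitution give far lower numbers than the amino-bearing compound 3.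

Compound 4 `CCCN(CCC)c1cc(C)nc2c(-c3ncc(N=O)cc3C)c(C)nn12` has not yet been measured. It differs from compound 3 as follows: a group of 2 heavy atoms (1 nitrogen, 1 oxygen; no ring) in place of one nitrogen atom, on an aromatic carbon. The change keeps the shared core and the dipropylamino chain intact and touches only the single substituent named above.

For the measured compounds named here, no measured pair shows this exact change. Given that compound 3 sits highest and that the amino group is the one feature setting it apart from the more potent compounds, a move to a lower number is expected, likely a moderate one, beyond the scatter but not reaching compound 1. Compound 4 is therefore estimated at 20 nM in this assay, with a range from 4 nM to 100 nM, corresponding to an expected step of a 4.3-fold lower number from compound 3 to compound 4 (0.63 log units; beyond the scatter).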

Compound 4, inhibition constant: 100 nM
Compound 4: middle estimate off by 5.0-fold (0.70 log units), on the low side; the range from low to high includes it.
By their numbers in this assay, from the lowest: compound 1; then compound 2; then compounds 3 and 4 (each within the scatter of the next).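

In this assay the group of 2 heavy atoms (1 nitrogen, 1 oxygen) in place of the amino group gives a 1.2-fold higher number from compound 3 to compound 4 (0.07 log units; within the scatter) at this position, on an aromatic carbon two atoms from the ring nitrogen and meta to a methyl group. Among the compounds shown here, this is the first single-place step available here: the substituent goes from 1 hydrogen-bond donor and 1 hydrogen-bond acceptor to 0 hydrogen-bond donors and 2 hydrogen-bond acceptors, and the number stays within the scatter, so this position accepts at least this one exchange of the amino group without a measurable difference. No supporting measurement accounts for this outcome.

Going by these compounds, whether a chlorine atom or a trifluoromethyl group at this same position, in a compound otherwise like compound 3, would give a number close to those of compound 1 and compound 2 remains open, as does the effect of replacing the methyl group with chlorine, the other place where those compounds differ from compound 3. How a nitrile or a methoxy group would behave at this position also remains to be seen.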